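Swapping a Halogenated Aryl Group on a Weak Cytotoxic Core

The compounds below may be only part of what the source reports. "The series", "measured", "known", "first", "only" and "open" are said of these compounds alone.

Compound 1 `C=CCn1c(=O)/c(=C\c2cccc(Br)c2)[nH]c(=O)/c1=C\c1ccccc1OC` is the anchor of this small set. For the measured compounds named here, in a functional assay on MOLT-4 cells (Homo sapiens) for cytotoxicity, read by CCK-8 assay, with a stated time of 72 h (on this read-out higher numbers stand for weaker inhibition and lower numbers for stronger inhibition), compound 1 gives 5000 nM, which is the only number reported for any compound here. Compound 2 `C=CCn1c(=O)/c(=C\c2cccc(Br)c2)[nH]c(=O)/c1=C\c1cccc(Br)c1` is recorded in this assay as "not active" (no number reported). Compound 3 `COc1ccccc1/C=c1/[nH]c(=O)/c(=C\c2nc[nH]c2C(C)(C)C)[nH]c1=O` has in this assay the entry "not determined" (no result reported). Going by the values given here, compound 1 therefore stands alone on the numbers; its result shows only weak inhibition, and no step between two measured values is available for comparison.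

Compound 4 `C=CCn1c(=O)/c(=C\c2ccccc2Cl)[nH]c(=O)/c1=C\c1ccccc1OC` differs from compound 1 in one place: 2-chlorophenyl in place of 3-bromophenyl on a double-bonded chain carbon bound to an aromatic carbon. Among the compounds with values here, with no measured step to lean on, the expectation rests on compound 1 alone. The step from compound 1 to compound 4 is expected to be a 1.2-fold higher number from compound 1 to compound 4 (0.08 log units; within the scatter), within the usual scatter and in no particular direction. Compound 4 is estimated in this assay at 6000 nM, with a range from 2000 nM to 20000 nM. An outcome reported only as inactive, as for compound 2, also remains possible.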

Compound 4, half-maximal inhibitory concentration: 4400 nM
For compound 4 the middle estimate is 1.4-fold (0.13 log units) above the measured one, and the stated range covers the measured number.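

In this assay the exchange of 3-bromophenyl for 2-chlorophenyl gives a 1.1-fold lower number from compound 1 to compound 4 (0.06 log units; within the scatter), so the two compounds cannot be told apart and the activity stays weak. For the compounds shown here, this is the first readable step at this position, and it shows that one halogenated phenyl can replace another here without a measurable difference, although the halogen and its place on the ring change together, so their separate contributions cannot be told apart. No supporting data bear on this result.

The compounds shown leave open whether a much different group at this position, such as a carboxylic acid or an amine, would move the number beyond the usual scatter. They also leave open how an unsubstituted phenyl would compare with these two halogenated groups.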